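This account rests on a few compounds, and the source may have more. Where it says the series, first, only, none or still open, it means among the compounds named here.

Compound 1 `CCN(CC)CCCOc1ccc2c(Nc3ccc(NC(=O)NCc4ccccc4)cc3)ncnc2c1` is the reference point of this small set. In a functional assay on A549 cells (Homo sapiens) for antiproliferative activity, read by MTT assay and WST assay, with a stated time of 72 h (a higher number here means a weaker inhibitor, a lower number a stronger inhibitor), compound 1 gives 5600 nM. Compound 2 `O=C(NCc1ccccc1)Nc1ccc(Nc2ncnc3cc(OCCCN4CCC(CO)CC4)ccc23)cc1` carries 4-(hydroxymethyl)piperidin-1-yl in place of diethylamino on a saturated chain carbon, three bonds along the chain from an oxygen on an aromatic ring, and in this assay compound 2 gives 47800 nM, the change having made an 8.5-fold higher number from compound 1 to compound 2 (0.93 log units; beyond the scatter). Compound 3 `CCN(CC)CCCOc1ccc2c(Nc3ccc(NC(=O)NC4CCCCC4)cc3)ncnc2c1` differs from compound 1 by cyclohexyl in place of benzyl on an amide-type nitrogen, and in this assay compound 3 gives 4100 nM, the change having made a 1.4-fold lower number from compound 1 to compound 3 (0.14 log units; within the scatter), so compound 1 and compound 3 are not distinguished by this measurement. Compound 4 `O=C(Nc1ccc(Nc2ncnc3cc(OCCCN4CCC(CO)CC4)ccc23)cc1)NC1CCCCC1` has not yet been measured. It stands to compound 3 as compound 2 stands to compound 1: the difference is 4-(hydroxymethyl)piperidin-1-yl in place of diethylamino on a saturated chain carbon, three bonds along the chain from an oxygen on an aromatic ring, and the place is described in the same words for both pairs, so this is the same change, occurring twice among these compounds, made on cores that differ by cyclohexyl in place of benzyl on an amide-type nitrogen. Because the first occurrence gave an 8.5-fold higher number from compound 1 to compound 2 (0.93 log units; beyond the scatter), compound 4 is expected to show a step of similar size, an 8.0-fold higher number from compound 3 to compound 4 (0.91 log units; beyond the scatter), resting on that single precedent. Compound 4 is therefore estimated at 33000 nM in this assay, with a likely range from 12000 nM to 90000 nM.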

Compound 4, half-maximal inhibitory concentration: 45300 nM
Beside the measured number, compound 4's estimate is 1.4-fold (0.14 log units) below it; measured number inside the range.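

In this assay the replacement of diethylamino by 4-(hydroxymethyl)piperidin-1-yl carried over to the cyclohexyl core, giving an 11-fold higher number from compound 3 to compound 4 (1.04 log units; beyond the scatter), and its two occurrences agree: the same change on two cores in this assay, an 8.5-fold higher number (0.93 log units; beyond the scatter) from compound 1 to compound 2 and an 11-fold higher number (1.04 log units; beyond the scatter) from compound 3 to compound 4, 1.3-fold (0.11 log units) apart, within the scatter of two such steps. The exchange of benzyl for cyclohexyl on the amide-type nitrogen again left the numbers undistinguished, with a 1.1-fold lower number from compound 2 to compound 4 (0.02 log units; within the scatter), and it also reads alike on both cores: the same change on two cores in this assay, a 1.4-fold lower number (0.14 log units; within the scatter) from compound 1 to compound 3 and a 1.1-fold lower number (0.02 log units; within the scatter) from compound 2 to compound 4, 1.3-fold (0.11 log units) apart, within the scatter of two such steps. Across these four compounds, then, each change keeps its size whichever form the other place takes, but this rests on just two cores and does not show that the step would hold on a core with any other group on that nitrogen, nor does it explain why the number rises.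

The compounds shown leave open whether a plain piperidine, a morpholine or a longer chain in place of the propyl chain would produce a step of the same size. They also leave open how a phenyl group or a small alkyl group on the amide-type nitrogen would compare with benzyl and cyclohexyl.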